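The source may report more compounds than this note shows. Statements on the series, on what has been measured and on what is new or still open speak of the compounds shown alone.

Measured so far:
- compound 1 `COc1ccc(OC)c(/C=N/NC(=O)Nc2ccc(Oc3ccnc(-c4nncn4CCN(C)C)c3)c(F)c2)c1`: 2930 nM
- compound 2 `COc1cc(/C=N/NC(=O)Nc2ccc(Oc3ccnc(-c4nncn4CCN(C)C)c3)c(F)c2)cc(OC)c1OC`: 2770 nM
- compound 3 `CN(C)CCn1cnnc1-c1cc(Oc2ccc(NC(=O)N/N=C/c3ccc(O)c(O)c3)cc2F)ccn1`: 1930 nM

In a functional assay on NCI-H460 cells (Homo sapiens) for cytotoxicity, read by MTT assay, with a stated time of 72 h (on this read-out higher numbers stand for weaker inhibition and lower numbers for stronger inhibition), compound 1 shows the highest number of the three, yet both others lie within the scatter of it: a 1.1-fold lower number from compound 1 to compound 2 (0.02 log units; within the scatter) and a 1.5-fold lower number from compound 1 to compound 3 (0.18 log units; within the scatter). Compound 4 `CN(C)CCn1cnnc1-c1cc(Oc2ccc(NC(=O)N/N=C/c3cccc(Br)c3)cc2F)ccn1` has not been measured. It differs from compound 1 in one place: 3-bromophenyl in place of 2,5-dimethoxyphenyl on a carbon with a double bond to nitrogen. For the measured compounds named here, the steps that bear on this are the two that exchange the same group on the same carbon, from compound 1 to compound 2 and from compound 1 to compound 3, both within the scatter, as is a 1.4-fold lower number from compound 2 to compound 3 (0.16 log units; within the scatter). A step of similar size is therefore expected, none beyond the scatter, in this assay: a 1.1-fold lower number from compound 1 to compound 4 (0.05 log units; within the scatter). Compound 4 is estimated at 2600 nM, with a range from 1000 nM to 7000 nM.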

Compound 4, half-maximal inhibitory concentration: 520 nM
The estimate for compound 4 lay 5.0-fold (0.70 log units) above the measured number; measured number outside the range, below it.
By their numbers in this assay, from the lowest: compound 4; then compounds 3, 2 and 1 (each within the scatter of the next).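

In this assay, for the compounds shown here, the group on this carbon with a double bond to nitrogen proves able to shift the number, which the earlier compounds, all within the scatter of one another, did not show. With 3-bromophenyl in place of each earlier ring, the number falls beyond the scatter every time (a 5.6-fold lower number from compound 1 to compound 4 (0.75 log units; beyond the scatter)), (a 5.3-fold lower number from compound 2 to compound 4 (0.73 log units; beyond the scatter)) and (a 3.7-fold lower number from compound 3 to compound 4 (0.57 log units; beyond the scatter)). Nothing available explains this gain. Whether the bromine itself matters remains open, since the compounds shown include no plain phenyl and no 3-chlorophenyl or 3-fluorophenyl on this carbon.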